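A few compounds are considered here, and "the series" means these few. Any claim that something is new, unique, unknown or untested is made for them only; others in the source may bear on it.

Measured compounds:
Compound 1, `Cc1cc(/C=C/c2ccc(O)cc2)[nH]n1`: 38800 nM
Compound 2, `COc1ccc(/C=C/c2cc(C)n[nH]2)cc1`: 9400 nM
Compound 3, `COc1ccc(/C=C/c2cc(C)no2)cc1`: 22400 nM

In a functional assay on HCT-116 cells (Homo sapiens) for cytotoxicity, read by MTT assay, with a stated time of 72 h (a higher number here means a weaker inhibitor, a lower number a stronger inhibitor), compound 2 gives 9400 nM, and compound 1 gives 38800 nM. The change between them is hydrogen in place of methyl on an oxygen on an aromatic ring; it produced a 4.1-fold higher number from compound 2 to compound 1 (0.62 log units; beyond the scatter). Compound 3, which gives 22400 nM in this assay, carries a different core from compound 2; how the two cores differ is not broken down here. Compound 4, `Cc1cc(/C=C/c2ccc(O)cc2)on1`, has not yet been measured. It differs from compound 3 by hydrogen in place of methyl on an oxygen on an aromatic ring, the same change as that from compound 2 to compound 1, made at a place described in the same words. Within the data shown here, with only one earlier instance of this change to go on, the step from compound 3 to compound 4 in this assay is expected to resemble the step from compound 2 to compound 1, giving an expected 3.3-fold higher number from compound 3 to compound 4 (0.52 log units; beyond the scatter), because the earlier step of a 4.1-fold higher number from compound 2 to compound 1 (0.62 log units; beyond the scatter) is the only guide. Compound 4 is therefore estimated at 75000 nM, with a likely range from 30000 nM to 200000 nM.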

Compound 4, half-maximal inhibitory concentration: 67900 nM
The estimate for compound 4 lay 1.1-fold (0.04 log units) above the measured number; the measured number falls inside the stated range.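

In this assay, going from methoxy to hydroxy gave a 3.0-fold higher number from compound 3 to compound 4 (0.48 log units; beyond the scatter), and the two steps can be set side by side: the same change on two cores in this assay, a 4.1-fold higher number (0.62 log units; beyond the scatter) from compound 2 to compound 1 and a 3.0-fold higher number (0.48 log units; beyond the scatter) from compound 3 to compound 4, 1.4-fold (0.13 log units) apart, within the scatter of two such steps Within this small series, then, the change carried from one core to the other, with the hydroxy compound giving the higher number, and so acting as the weaker inhibitor, in both pairs and by a similar amount on each core. Among these compounds, this rests on only two pairs, however, and it does not show that the change would behave the same way on any further core, nor does it explain why the number rises.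

The compounds shown leave open what would follow if an ethyl group or a longer chain took the place of the methyl on that oxygen, or if an amine stood in place of the hydroxy. They also leave open whether the agreement between the two cores would hold outside this assay.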